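Cytotoxicity notes: nitro in place of hydrogen on compound 2

A few compounds are considered here, and "the series" means these few. Any claim that something is new, unique, unknown or untested is made for them only; others in the source may bear on it.

Of the compounds shown here, two have been read so far in an ADME assay on J774 cells (Mus musculus) for cytotoxicity, read by MTT assay, with a stated time of 48 h (on this read-out lower numbers stand for stronger inhibition and higher numbers for weaker inhibition), and neither yet gives a trend. Compound 1 `[O-][n+]1onc2ccc(/C=C/[S+]([O-])c3ccccc3)cc21` gives 30000 nM; > 400000 nM (2 entries) in this assay and these several entries do not amount to a single number. Among the measured compounds shown here, compound 2 `O=C(/C=C/c1ccc2no[n+]([O-])c2c1)c1ccccc1` gives 47000 nM as the only single number, and it serves as the reference point for the next compound.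

Compound 3 `O=C(/C=C/c1ccc2no[n+]([O-])c2c1)c1ccc([N+](=O)[O-])cc1` departs from compound 2 by one change, nitro in place of hydrogen on an aromatic carbon in plain terms nitro in place of hydrogen on an aromatic carbon, para to a large group. For the measured compounds named here, no measured pair shows what this replacement does in this assay so the expectation rests on compound 2 with its 47000 nM alone. A modest shift toward stronger inhibition is expected, and a result within the usual scatter would not be surprising. The expected size is a 1.6-fold lower number from compound 2 to compound 3 (0.19 log units; within the scatter) as a rough estimate only. For compound 3 the estimated value is 30000 nM with 10000 nM to 100000 nM as the expected range.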

Compound 3, half-maximal inhibitory concentration: 32000 nM
Estimate against measurement, compound 3: 1.1-fold (0.03 log units) below; the measured number falls inside the stated range.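

In this assay, nitro in place of hydrogen on an aromatic carbon, para to a large group, gives a 1.5-fold lower number from compound 2 to compound 3 (0.17 log units; within the scatter), so the two compounds cannot be told apart on this read-out. Among the compounds shown here, this is the first step between measured compounds that differ in one place, and it shows that this place on the six-membered aromatic ring of carbon only can carry a nitro group with no change in cytotoxicity beyond the usual scatter of the measurement. The measurements at hand offer no explanation for this step.

One substituent at one place cannot show whether the flat reading belongs to this place in general or to nitro alone, and an amine, a carboxylic acid or a methoxy group at the same carbon would test that directly. Also open, going by these compounds, is whether the same replacement on another carbon of this ring would stay within the scatter, and whether a reading that departs clearly from that of compound 2 can be reached by any change on this ring at all.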